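Removing one chloro from the core of compound 1

The source may hold more compounds than are shown below. What is called first, only, known or untested is meant among the compounds shown, and "the series" means these compounds.

Measured compounds:
compound 1, `O=C(NCCCCc1ccccc1)n1c(=O)oc2cc(Cl)c(Cl)cc21`, 18 nM
compound 2, `O=C(NCCCCCc1ccccc1)n1c(=O)oc2ccccc21`, 54 nM
compound 3, `O=C(NCCCCc1ccc([N+](=O)[O-])cc1)n1c(=O)oc2ccccc21`, 312 nM

Of the compounds shown here, three have been measured in an assay on HEK293 cells for inhibition of acid ceramidase (Homo sapiens), with a stated time of 10 min; a lower number here means a stronger inhibitor, a higher number a weaker inhibitor. Compound 1 gives 18 nM, the lowest of the three numbers. Compound 2, which carries a longer chain and an unsubstituted core, gives 54 nM, a gap to compound 1 that lies beyond the scatter. Compound 3, with a nitro group on its terminal phenyl ring and an unsubstituted core, gives 312 nM, the highest number of the set. Among the compounds with values here, neither of these pairs differs from compound 1 in only one place, so no single step has been isolated.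

Compound 4, `O=C(NCCCCc1ccccc1)n1c(=O)oc2cc(Cl)ccc21`, is not yet measured. It differs from compound 1 in one place: hydrogen in place of chloro on an aromatic carbon. Both measured comparators with an unsubstituted core sit higher than compound 1, though each also changes elsewhere, so the one chloro dropped here is expected to cost some potency, but less than the gap from compound 1 to compound 2. The step from compound 1 to compound 4 is estimated as a 1.9-fold higher number from compound 1 to compound 4 (0.29 log units; within the scatter), toward a higher number. Compound 4 is expected to give 35 nM, within a range from 12 nM to 100 nM.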

Compound 4, half-maximal inhibitory concentration: 33 nM
The estimate for compound 4 lay 1.1-fold (0.03 log units) above the measured number, within the range that was stated.
By their numbers in this assay, from the lowest: compounds 1, 4 and 2 (each within the scatter of the next, the first and the last beyond it); then compound 3.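

In this assay, within the data shown here, the pair of compound 1 and compound 4 is the first in the set to differ in one place only, and it gives a 1.8-fold higher number from compound 1 to compound 4 (0.26 log units; within the scatter) for hydrogen in place of chloro on an aromatic carbon. The earlier compounds shown here could not separate the core from the chain or the terminal phenyl ring, whereas this pair shows that losing this one chloro, ortho to the other chloro group, does not move the number beyond the scatter. Nothing available here bears on why this change has so small an effect.

The compounds shown leave open what happens when the remaining chloro is also replaced by hydrogen while the chain stays as in compound 1. They also leave open whether a fluoro, methyl or methoxy group at this same position would give a number apart from that of compound 1.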